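The source may hold more compounds than are shown below. What is called first, only, known or untested is meant among the compounds shown, and "the series" means these compounds.

The measured compounds, each with its reading in a physicochemical assay for solubility, at pH 7.4; a higher number here means a more soluble compound, a lower number a less soluble compound:

Compound 1 `CC(C)Nc1nc(NCc2ccco2)c2ccc(Cl)cc2n1`: in this assay compound 1 is reported only as a limit, <= 20000 nM.
Compound 2 `Cc1cccc2c(NCc3ccco3)nc(NC(C)C)nc12`: in this assay compound 2 is likewise reported only as a limit, <= 20000 nM.
Compound 3 `Cc1ccc2nc(NC(C)C)nc(NCc3ccco3)c2c1`: in this assay compound 3 is also reported only as a limit, <= 20000 nM.

Compound 1 therefore stands nowhere in particular among the three: its reading is a limit, not a number, and the same holds for compound 2 and compound 3, all three sitting at the limit of <= 20000 nM in this assay, at which 3 of the 3 values shown sit. Within the data shown here, with no number for any of them, no step between measured compounds can be given, and none of the three can be called more or less soluble than another.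

Compound 4 `COc1ccc2c(NCc3ccco3)nc(NC(C)C)nc2c1` differs from compound 1 in a single place: methoxy in place of chloro on an aromatic carbon. Among the measured compounds shown here, no measured pair shows a change of this kind, so there is nothing to set its size against; given that every reading so far is a limit, the step from compound 1 to compound 4 is expected to be none beyond the scatter, estimated as a number no lower from compound 1 to compound 4 (the limit leaves the size open). Compound 4 is thus expected to come out at about 20000 nM, with a range from 8000 nM to 20000 nM, most likely again as a limit.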

Compound 4, solubility: <= 20000 nM
Compound 4 gave a limit, no number (the forecaster's own chance of this, stated with the estimate: 80%); the middle value lies on the limit itself.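

Compound 1 and compound 4 are both reported only as limits in this assay, so no step from one to the other can be read: the limit of <= 20000 nM in this assay, at which 4 of the 4 values shown sit.

The compounds shown leave open whether methoxy in place of chloro on an aromatic carbon changes the reading at all, and how the four compounds rank in this assay.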